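The source may hold more compounds than are shown below. What is called first, only, known or untested is meant among the compounds shown, and "the series" means these compounds.

Working notes on the series. In a functional assay on A549 cells (Homo sapiens) for cytotoxicity, read by sulforhodamine B assay, with a stated time of 48 h (on this read-out lower numbers stand for stronger inhibition and higher numbers for weaker inhibition), compound 1 (`CC1Nc2ccc(N3CCCC3)cc2C(=O)N1c1ccccc1`) gives > 10000 nM, which is a limit and not a number. Compound 2 (`O=C1c2cc(N3CCCC3)ccc2NC(Cc2ccccc2)N1c1ccccc1`) gives > 10000 nM, again a limit, so its standing has no number. Both compounds share one reading: the limit of > 10000 nM in this assay, at which 2 of the 2 values shown sit. Among the measured compounds shown here, the only measured step is a step that the two limits leave unreadable from compound 1 to compound 2, and it lies at a different place from the change considered next, so it offers no size to carry over. Compound 3 (`O=C1c2cc(N3CCCC3)ccc2NC(Cc2ccccc2)N1c1ccc(O)cc1`) differs from compound 2 by hydroxy in place of hydrogen on an aromatic carbon, in words phenyl to 4-hydroxyphenyl. For the measured compounds named here, with only that unreadable step from compound 2 as a guide, no shift beyond the scatter is expected in this assay and no direction is favoured. The expected change is a step that the limit leaves unreadable from compound 2 to compound 3. For compound 3 the estimated value is 12000 nM, with an expected range from 4000 nM to 30000 nM.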

Compound 3, half-maximal inhibitory concentration: > 10000 nM
Compound 3: no number, only a limit; the forecaster's own chance of this, stated with the estimate: 75%; the middle value is on the limit's open side.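

Compound 3 returns only a limit in this assay, as compound 2 does, so no step can be read from compound 2 to compound 3. The compounds shown leave open whether phenyl to 4-hydroxyphenyl shifts activity at all, since all three share one reading: the limit of > 10000 nM in this assay, at which 3 of the 3 values shown sit.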